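The compounds below may be only part of what the source reports. "The series", "measured", "known", "first", "only" and "open" are said of these compounds alone.

Measured so far:
compound 1, `O=[N+]([O-])c1cccc(-c2nn(-c3ccccc3)cc2C(Nc2nc3ccccc3s2)c2c(O)ccc3ccccc23)c1`: 8220 nM
compound 2, `Cc1ccc2nc(NC(c3cn(-c4ccccc4)nc3-c3cccc([N+](=O)[O-])c3)c3c(O)ccc4ccccc34)sc2c1`: 7360 nM
compound 3, `Cc1ccc(-c2nn(-c3ccccc3)cc2C(Nc2nc3cc(C)c(C)cc3s2)c2c(O)ccc3ccccc23)cc1`: 17800 nM

In a functional assay on HeLa cells (Homo sapiens) for antiproliferative activity, read by MTT assay, with a stated time of 48 h (a lower number here means a stronger inhibitor, a higher number a weaker inhibitor), compound 1 gives 8220 nM and stands second highest of the three numbers; compound 2 lies nearest, a 1.1-fold lower number from compound 1 to compound 2 (0.05 log units; within the scatter), and compound 3 furthest, with a higher number beyond the scatter.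

Compound 4, `Oc1ccc2ccccc2c1C(Nc1nc2ccccc2s1)c1cn(-c2ccccc2)nc1-c1ccccc1`, is not yet measured. It differs from compound 1 by hydrogen in place of nitro on an aromatic carbon, on an aromatic carbon of a six-membered aromatic ring of carbon only. Among the compounds with values here, no measured step covers this change alone: the only step in hand, from compound 1 to compound 2, concerns a methyl on a different ring and lies within the scatter. Compound 3 carries a methyl where compound 1 carries nitro, but also two further methyls, so its higher number cannot be assigned to one change. Removal of the nitro is therefore expected to leave compound 4 near compound 1 or somewhat weaker, a 1.5-fold higher number from compound 1 to compound 4 (0.16 log units; within the scatter). For compound 4 the expected value is 12000 nM, between 5000 nM and 30000 nM.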

Compound 4, half-maximal inhibitory concentration: 17300 nM
Compound 4: the middle estimate sits 1.4-fold (0.16 log units) below what was measured, within the range that was stated.
By their numbers in this assay, from the lowest: compounds 2 and 1 (each within the scatter of the next); then compounds 4 and 3 (each within the scatter of the next).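

In this assay, replacing 3-nitrophenyl with phenyl gives a 2.1-fold higher number from compound 1 to compound 4 (0.32 log units; beyond the scatter), so this position on the six-membered carbon ring responds to the change, if only modestly. Within the data shown here, this is the first single change to clear the scatter, whereas the methyl step on the other ring, a 1.1-fold lower number from compound 1 to compound 2 (0.05 log units; within the scatter), does not. Nothing available explains why the compound with the nitro group gives the lower number.

As far as these compounds go, it remains open whether the lower number is specific to nitro or would also appear with another group at this place, such as an amine or a carboxylic acid. Also open, from the compounds shown here alone, is whether nitro would give a similar step elsewhere on this ring, or with the methyl on the other ring present.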